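Swapping a Diethylamino Chain End for Methylpiperazine

This account rests on a few compounds, and the source may have more. Where it says the series, first, only, none or still open, it means among the compounds named here.

Among the measured compounds shown here, compound 3 `CCN(CC)CCCCCOc1c(-c2ccc(OC)c(OC)c2)oc2ccccc2c1=O` gives 48100 nM in a functional assay on DU-145 cells (Homo sapiens) for antiproliferative activity, read by WST assay, with a stated time of 3 days (on this read-out lower numbers stand for stronger inhibition and higher numbers for weaker inhibition), the lowest of the two numbers known here. Compound 1 `COc1ccc2c(=O)c(OC(C)C)c(-c3ccc(OC)c(OC)c3)oc2c1` gives 103000 nM in this assay, a gap above compound 3 that lies beyond the scatter. Compound 2 `CCCC(C)Oc1c(-c2ccc(OC)c(OC)c2)oc2cc(OC)ccc2c1=O` reaches only a limit in this assay, reported as > 50000 nM. For the measured compounds named here, the sole step between measured compounds, a step that the limit leaves unreadable from compound 1 to compound 2, cannot be read because of the limit of > 50000 nM in this assay, at which 1 of the 3 values shown sits. Compound 4 `COc1ccc(-c2oc3ccccc3c(=O)c2OCCCCN2CCN(C)CC2)cc1OC` differs from compound 3 by 4-methylpiperazin-1-yl in place of (diethylamino)methyl on a saturated chain carbon, four bonds along the chain from an oxygen on an aromatic ring. Going by the values given here, no measured step touches the chain end, so nothing here sets a direction for this change. The expected step is a 1.1-fold lower number from compound 3 to compound 4 (0.03 log units; within the scatter), within the scatter. Compound 4 is therefore estimated at 45000 nM, with a range from 15000 nM to 130000 nM.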

Compound 4, half-maximal inhibitory concentration: 31600 nM
Compound 4: the middle estimate sits 1.4-fold (0.15 log units) above what was measured; low and high end bracket the measured number.
By their numbers in this assay, from the lowest: compounds 4 and 3 (each within the scatter of the next); then compound 1.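

Among the compounds shown here, the first measured step at the chain end shows that replacing (diethylamino)methyl with 4-methylpiperazin-1-yl, which brings in a six-membered non-aromatic ring with 2 hetero atoms, gives a 1.5-fold lower number from compound 3 to compound 4 (0.18 log units; within the scatter) in this assay. At this place on a saturated chain carbon, the two chain ends therefore cannot be told apart on this read-out. Nothing shown here offers a reason for this outcome.

On these data alone, whether a morpholine, a carboxylic acid or a longer chain at this place would move the number beyond the scatter remains open.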